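A few compounds are considered here, and "the series" means these few. Any claim that something is new, unique, unknown or untested is made for them only; others in the source may bear on it.

Measured so far:
compound 1 `CCOC(=O)C1=C(Nc2ccccc2)S/C(=C\c2ccccc2)C1=O` — 20.3%
compound 2 `CCOC(=O)C1=C(Nc2ccccc2Br)S/C(=C\c2ccc[nH]2)C1=O` — 62.7%
compound 3 `CCOC(=O)C1=C(Nc2ccc(C(F)(F)F)cc2)S/C(=C\c2ccc[nH]2)C1=O` — 38.5%

All three were run in a functional assay on JAR cells (Homo sapiens) for inhibition, read by MTT assay, with a stated time of 72 h, tested at 10 uM; on this read-out lower numbers stand for less inhibition and higher numbers for more inhibition at the one concentration tested (going by the name of the read-out). Compound 1 gives the lowest of the three numbers; compound 3 stands nearest, higher by a margin beyond the scatter, and compound 2 stands furthest, also beyond the scatter. Among the measured compounds shown here, no single-change step between measured compounds is available: compound 2 and compound 3 each differ from compound 1 in more than one place, so their higher numbers cannot be assigned to one change.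

Compound 4 `CCOC(=O)C1=C(Nc2ccccc2)S/C(=C\c2cc3ncccc3[nH]2)C1=O` differs from compound 1 in one place only:
a group of 9 heavy atoms (7 carbon, 2 nitrogen; one five-membered aromatic ring with 1 hetero atom, one six-membered aromatic ring with 1 hetero atom) in place of a group of 6 heavy atoms (6 carbon; one six-membered aromatic ring of carbon only), on a double-bonded chain carbon bound to a double-bonded ring carbon

For the measured compounds named here, no measured pair isolates this exchange. Compound 2 with 62.7% and compound 3 with 38.5% both lack the phenyl at this position and both stand above compound 1, but each also differs elsewhere, so that reading is indirect. On that basis the step in this assay from compound 1 to compound 4 is expected to be an increase, of moderate size, likely beyond the scatter, with wide uncertainty. For compound 4 the expected value is 35%, within 15% to 55%. The estimated step of a number 14.7 percentage points higher from compound 1 to compound 4 (beyond the scatter) rests only on the indirect comparison above.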

Compound 4, a percentage reported as inhibition, at one concentration (the size of the read-out at that concentration, not a potency): 74.8%
The estimate for compound 4 lay 39.8 percentage points below the measured number; measured number above the stated range.
By their numbers in this assay, from the lowest: compound 1; then compound 3; then compound 2; then compound 4.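

The exchange of phenyl for the group of 9 heavy atoms, on a double-bonded chain carbon bound to a double-bonded ring carbon, gives a number 54.5 percentage points higher from compound 1 to compound 4 (beyond the scatter) in this assay. Among the compounds shown here, this is the first reading of this position on its own, with the rest of compound 1 unchanged, and it shows that a change here alone can produce a large step, which compound 2 and compound 3, each differing from compound 1 in more than one place, could not show. The entering group differs from phenyl at once in its ring count, its nitrogen atoms, its hydrogen-bond donor and its hydrogen-bond acceptor, and no measurement available here bears on which of these features goes with the step.

The compounds shown do not separate the larger ring system from its nitrogen atoms: an all-carbon indolyl group or a single pyridyl ring at this place, each on the core of compound 1, would be the direct comparisons. Also open, as far as these compounds go, is whether the step would persist with a carboxylic acid in place of the ethyl ester, and how it would read as a potency rather than at one concentration.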